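Swapping the Aryl Group on a Fused Core

A few compounds are considered here, and "the series" means these few. Any claim that something is new, unique, unknown or untested is made for them only; others in the source may bear on it.

Of the compounds shown here, three sharing one core have been measured in an assay on HEK-293T cells for displacement of a labelled ligand from corticotropin-releasing factor receptor 2 (Homo sapiens), read by scintillation counting, with a stated time of 2 h, tested at 1 uM; a higher number here means more inhibition at the concentration tested (going by the name of the read-out), a lower number less inhibition. Compound 1 `CCCCN(CC)c1cc(C)nc2c1NC(=O)CN2c1ccc(C)cc1C` gives 6.8%. Compound 2 `CCCCN(CC)c1cc(C)nc2c1NC(=O)CN2c1ccc(OC)cc1C` gives -2.3%. Compound 3 `CCCCN(CC)c1cc(C)nc2c1NC(=O)CN2c1ccc(Cl)cc1Cl` gives 0.9%. Compound 3 therefore stands second highest of the three numbers, with compound 2 nearest and compound 1 furthest, yet the step of a number 5.9 percentage points lower from compound 1 to compound 3 (within the scatter) and the step of a number 3.2 percentage points higher from compound 2 to compound 3 (within the scatter) both fall within the scatter, so the three numbers cannot be told apart.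

The next compound, compound 4 `CCCCN(CC)c1cc(C)nc2c1NC(=O)CN2c1ccc(Br)cc1C`, has not yet been measured. It differs from compound 3 in one place: 4-bromo-2-methylphenyl in place of 2,4-dichlorophenyl on a nitrogen on an aromatic ring in a ring. Within the data shown here, the steps that bear on this change are the two that also exchange the group on that ring nitrogen, a number 5.9 percentage points lower from compound 1 to compound 3 (within the scatter) and a number 3.2 percentage points higher from compound 2 to compound 3 (within the scatter); both lie within the scatter, and the single exchange a number 9.1 percentage points lower from compound 1 to compound 2 (within the scatter) does too. Among the measured compounds shown here, nothing among the measured compounds suggests that exchanging this group moves the inhibition in this assay beyond the scatter. The expected step of a number 2.1 percentage points higher from compound 3 to compound 4 (within the scatter) is therefore small. For compound 4 the estimate in this assay is 3%, with a range from -8% to 14%.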

Compound 4, a percentage reported as inhibition, at one concentration (the size of the read-out at that concentration, not a potency): 5.9%
Compound 4: middle estimate off by 2.9 percentage points, on the low side; the range from low to high includes it.
By their numbers in this assay, from the lowest: compounds 2, 3, 4 and 1 (each within the scatter of the next).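

In this assay, among these compounds, the bromo group fits the picture the earlier compounds gave: exchanging the whole aryl group on the ring nitrogen gives a number 5 percentage points higher from compound 3 to compound 4 (within the scatter), bromo in place of methoxy on an aromatic carbon gives a number 8.2 percentage points higher from compound 2 to compound 4 (within the scatter), and bromo in place of methyl on an aromatic carbon gives a number 0.9 percentage points lower from compound 1 to compound 4 (within the scatter). A fourth group at this place, 4-bromo-2-methylphenyl, thus joins the other three without any step leaving the scatter, so the four compounds cannot be told apart at the single concentration tested. No measurement at hand offers a reason for this result.

Going by these compounds, all the groups compared here are phenyl rings carrying only methyl, methoxy, chloro or bromo, so it remains open whether a carboxylic acid or an amine on an aromatic carbon, in place of the bromo, would move the number beyond the scatter. On these data alone, it also remains open whether these same compounds would separate from one another at a different concentration.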